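This account rests on a few compounds, and the source may have more. Where it says the series, first, only, none or still open, it means among the compounds named here.

Measured so far in a functional assay on the whole organism with Rattus norvegicus as the target; a lower number here means that less compound is needed, a higher number that more compound is needed for the effect:
compound 1 `CCOC(=O)C(=O)Nc1cccc(N)c1C#N` gives 0.05 mg/kg
compound 2 `CCOC(=O)C(=O)Nc1cccc([N+](=O)[O-])c1C#N` gives 0.4 mg/kg
compound 3 `CCOC(=O)C(=O)Nc1cccc(OC(C)C)c1C#N` gives 2 mg/kg

Compound 1 stands lowest of the three numbers. Its nearest neighbour is compound 2, with an 8.0-fold higher number from compound 1 to compound 2 (0.90 log units; beyond the scatter); its furthest is compound 3, with a 40-fold higher number from compound 1 to compound 3 (1.60 log units; beyond the scatter). Between the two other compounds the step is a 5.0-fold higher number from compound 2 to compound 3 (0.70 log units; beyond the scatter).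

Compound 4 `CCOC(=O)C(=O)Nc1cccc(F)c1C#N` has not yet been measured in this assay. It differs from compound 1 in one place: fluoro in place of amino on an aromatic carbon. Both measured steps that start from compound 1 bear on this change, since each also replaces the amino group at the same place with a different group, and each raised the number, modestly in an 8.0-fold higher number from compound 1 to compound 2 (0.90 log units; beyond the scatter) and by a large margin in a 40-fold higher number from compound 1 to compound 3 (1.60 log units; beyond the scatter). Neither replacement left the number where compound 1 has it, so a higher number is expected for compound 4 as well, beyond the scatter, of a size between those two steps. Compound 4 is therefore estimated at 0.4 mg/kg, with a range of 0.1 mg/kg to 1.6 mg/kg. This estimate means an expected step of an 8.0-fold higher number from compound 1 to compound 4 (0.90 log units; beyond the scatter).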

Compound 4, dose for half-maximal effect: 1.2 mg/kg
For compound 4 the middle estimate is 3.0-fold (0.48 log units) below the measured one, within the range that was stated.
By their numbers in this assay, from the lowest: compound 1; then compound 2; then compounds 4 and 3 (each within the scatter of the next).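

In this assay, fluoro replaces amino with the same count of heavy atoms, yet the change gives a 24-fold higher number from compound 1 to compound 4 (1.38 log units; beyond the scatter), so a single heavy atom at this place does not hold the number where compound 1 has it. Against nitro the step is a 3.0-fold higher number from compound 2 to compound 4 (0.48 log units; beyond the scatter), whereas against isopropoxy it is a 1.7-fold lower number from compound 3 to compound 4 (0.22 log units; within the scatter), so fluoro and isopropoxy cannot be told apart here, while nitro stands clear of both. All three replacements of amino now raise the number beyond the scatter, leaving compound 1 lowest of the four.

No available evidence bears on why amino stands apart from these three groups. From the compounds shown here alone, whether the amino hydrogens themselves matter stays open; methylamino, dimethylamino or hydroxyl at this place would bear on that.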